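Swapping the aryl group on the piperazine of compound 3

The source may hold more compounds than are shown below. What is called first, only, known or untested is meant among the compounds shown, and "the series" means these compounds.

Measured compounds:
compound 1, `Nc1scc(CN2CCN(c3ccc(Cl)c(C(F)(F)F)c3)CC2)c1C(=O)c1ccc(Cl)cc1`, -60%
compound 2, `Nc1scc(CN2CCN(c3ccc(OC(F)(F)F)cc3)CC2)c1C(=O)c1ccc(Cl)cc1`, -74%
compound 3, `Nc1scc(CN2CCN(c3ccc(F)cc3F)CC2)c1C(=O)c1ccc(Cl)cc1`, -82%

All three share one core and differ only in the aryl group on an amine nitrogen in a ring. In a functional assay on CHO cells with adenosine receptor A1 (Homo sapiens) as the target, read by cAMP accumulation and immunoassay, with a stated time of 6 min, tested at 10 uM (a lower number here means a stronger effect, a higher number a weaker effect of the compound at the concentration tested), compound 3 gives -82%, the lowest of the three numbers; compound 2 lies close by, within the scatter, while compound 1 lies beyond it, as the step of a number 22 percentage points lower from compound 1 to compound 3 (beyond the scatter) shows.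

Compound 4, `Nc1scc(CN2CCN(c3ccc(Cl)c(Cl)c3)CC2)c1C(=O)c1ccc(Cl)cc1`, has not yet been measured. It differs from compound 3 in one place: 3,4-dichlorophenyl in place of 2,4-difluorophenyl on an amine nitrogen in a ring

Among the measured compounds shown here, no measured step involves a 3,4-dichlorophenyl group, so the closest guides are the steps that lead to compound 3. The step of a number 22 percentage points lower from compound 1 to compound 3 (beyond the scatter) was modest but beyond the scatter, and the step of a number 8 percentage points lower from compound 2 to compound 3 (within the scatter) stayed within it. Compound 1, with a chlorine-bearing aryl group, gave the weakest effect, so a drift back toward compound 1 is plausible for compound 4, though not certain. An estimated step of a number 12 percentage points higher from compound 3 to compound 4 (beyond the scatter) is therefore expected, a slight weakening within or just beyond the scatter. The expected value for compound 4 in this assay is -70%, with a range from -86% to -52%.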

Compound 4, a percentage reported as activity, at one concentration (the size of the read-out at that concentration, not a potency): -62%
Beside the measured number, compound 4's estimate is 8 percentage points below it, and the stated range covers the measured number.
By their numbers in this assay, from the lowest: compounds 3 and 2 (each within the scatter of the next); then compounds 4 and 1 (each within the scatter of the next).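

In this assay, 3,4-dichlorophenyl in place of 2,4-difluorophenyl on an amine nitrogen in a ring gives a number 20 percentage points higher from compound 3 to compound 4 (beyond the scatter), and the same group in place of 4-(trifluoromethoxy)phenyl gives a number 12 percentage points higher from compound 2 to compound 4 (beyond the scatter). Among the compounds shown here, compounds 1 and 4 also provide the first comparison in which a single group on the aryl ring changes while the rest of that ring stays the same, and chloro in place of trifluoromethyl on an aromatic carbon gives only a number 2 percentage points lower from compound 1 to compound 4 (within the scatter). Among these four compounds, the two aryl groups that carry chlorine, 4-chloro-3-(trifluoromethyl)phenyl and 3,4-dichlorophenyl, therefore go with the higher numbers, and no compound shown goes against this.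

From the compounds shown here alone, whether an unsubstituted phenyl group, a methoxy group on the aryl ring or a pyridine ring in the same place would fit this pattern remains open, as does the effect of any change to the shared core. Nothing given here accounts for the difference between these aryl groups.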